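The source may report more compounds than this note shows. Statements on the series, on what has been measured and on what is new or still open speak of the compounds shown alone.

Measured compounds: compound 1 `CN(C)CCn1cnnc1-c1cc(Oc2ccc(NC(=O)N/N=C/c3ccc(F)cc3)cc2F)ccn1`, compound 2 `CN(C)CCn1cnnc1-c1cc(Oc2ccc(NC(=O)N/N=C/c3cccc(Br)c3)cc2F)ccn1`, compound 3 `CN(C)CCn1cnnc1-c1cc(Oc2ccc(NC(=O)N/N=C/c3ccc(F)cc3Cl)cc2F)ccn1`. In a functional assay on NCI-H460 cells (Homo sapiens) for cytotoxicity, read by MTT assay, with a stated time of 72 h (a lower number here means a stronger inhibitor, a higher number a weaker inhibitor), compound 1 gives 1980 nM, compound 2 gives 520 nM, and compound 3 gives 720 nM. Compound 3 stands second highest of the three numbers: a 1.4-fold higher number from compound 2 to compound 3 (0.14 log units; within the scatter), whereas a 2.8-fold lower number from compound 1 to compound 3 (0.44 log units; beyond the scatter). Compound 4 is `CN(C)CCn1cnnc1-c1cc(Oc2ccc(NC(=O)N/N=C/c3ccc(O)cc3O)cc2F)ccn1`; the change is 2,4-dihydroxyphenyl in place of 2-chloro-4-fluorophenyl on a carbon with a double bond to nitrogen. Going by the values given here, none of the measured steps exchanges halogens for hydroxyls on this ring; a 3.8-fold lower number from compound 1 to compound 2 (0.58 log units; beyond the scatter) and a 2.8-fold lower number from compound 1 to compound 3 (0.44 log units; beyond the scatter) show only that substituent changes here move this assay modestly, so the present change is expected to be no larger than that and of uncertain direction. Compound 4 is therefore expected to show a 1.4-fold higher number from compound 3 to compound 4 (0.14 log units; within the scatter). The estimate for compound 4 is 1000 nM, within 300 nM to 3500 nM.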

Compound 4, half-maximal inhibitory concentration: 11300 nM
Beside the measured number, compound 4's estimate is 11-fold (1.05 log units) below it; the whole stated range lies below it.
By their numbers in this assay, from the lowest: compounds 2 and 3 (each within the scatter of the next); then compound 1; then compound 4.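

In this assay the 2,4-dihydroxyphenyl group on this carbon gives a clear loss against all three halogenated rings (a 16-fold higher number from compound 3 to compound 4 (1.20 log units; beyond the scatter); a 22-fold higher number from compound 2 to compound 4 (1.34 log units; beyond the scatter); a 5.7-fold higher number from compound 1 to compound 4 (0.76 log units; beyond the scatter)). Two of these steps are large, whereas the steps among the halogenated compounds stayed modest or within the scatter, so this position tolerates far larger shifts in the number than those compounds showed. Nothing available bears on the cause of this loss.

From the compounds shown here alone, whether a single hydroxyl on this ring carries the loss remains open. So does whether methoxy or amino groups in place of the two hydroxyls behave the same way.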